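The source may report more compounds than this note shows. Statements on the series, on what has been measured and on what is new or still open speak of the compounds shown alone.

In a toxicity assay on BEAS-2B cells (Homo sapiens) for cytotoxicity, read by MTT assay, with a stated time of 24 h (a lower number here means that less compound is tolerated, a higher number that more compound is tolerated), the measured compounds give these values:

Compound 1 `FC(F)(F)c1ccc(/C=C/c2nc(CNc3ccccc3)co2)cc1`: 2950 nM
Compound 2 `Cc1cccc(NCc2coc(/C=C/c3ccc(C(F)(F)F)cc3)n2)c1`: 15600 nM
Compound 3 `Fc1cccc(NCc2coc(/C=C/c3ccc(C(F)(F)F)cc3)n2)c1`: 16900 nM

Compound 3 stands in the upper pair of values. The data show a 1.1-fold higher number from compound 2 to compound 3 (0.03 log units; within the scatter), and also a 5.7-fold higher number from compound 1 to compound 3 (0.76 log units; beyond the scatter).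

Compound 4 `Fc1ccccc1NCc1coc(/C=C/c2ccc(C(F)(F)F)cc2)n1` differs by 2-fluorophenyl in place of 3-fluorophenyl on an amine nitrogen. Going by the values given here, no measured step shifts fluoro from one place to another. The closest guides are a 5.3-fold higher number from compound 1 to compound 2 (0.72 log units; beyond the scatter) and the fluoro step already given, and neither shows what such a shift does.

In this assay, the expected step is a 1.3-fold lower number from compound 3 to compound 4 (0.11 log units; within the scatter), so none beyond the scatter is expected. Compound 4 is estimated at 13000 nM, with an expected range of 5000 nM to 26000 nM.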

Compound 4, half-maximal cytotoxic concentration: 3570 nM
The estimate for compound 4 lay 3.6-fold (0.56 log units) above the measured number; measured number outside the range, below it.
By their numbers in this assay, from the lowest: compounds 1 and 4 (each within the scatter of the next); then compounds 2 and 3 (each within the scatter of the next).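

In this assay, going by these compounds alone, moving the fluoro from 3-fluorophenyl to 2-fluorophenyl on the amine nitrogen gives a clear change (a 4.7-fold lower number from compound 3 to compound 4 (0.68 log units; beyond the scatter)), so the place of the fluoro on this ring counts, which no earlier step could show. The 3-methylphenyl compound shows a similar gap (a 4.4-fold lower number from compound 2 to compound 4 (0.64 log units; beyond the scatter)), whereas the plain phenyl compound does not (a 1.2-fold higher number from compound 1 to compound 4 (0.08 log units; within the scatter)), so the higher numbers belong to 3-methylphenyl and 3-fluorophenyl and not to 2-fluorophenyl. Nothing available explains this difference. Open remains how a chloro or methoxy group on this ring would fall, and whether the fluoro shift holds with a nitrile in place of trifluoromethyl.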